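Swapping Amino for Fluoro: What Compound 4 Might Show

A few compounds are considered here, and "the series" means these few. Any claim that something is new, unique, unknown or untested is made for them only; others in the source may bear on it.

Compound 1 `CC(=O)OC(C)n1cnc2c(Cl)nc(N)nc21` and compound 2 `CC(=O)OC(C)n1cnc2c(Cl)nc(F)nc21` share one core, while compound 3 `CC(=O)OCCOn1cnc2c(S)nc(N)nc21` and compound 4 `CC(=O)OCCOn1cnc2c(S)nc(F)nc21` share another; the difference between the two cores is not broken down here.

In a functional assay on L1210 cells (Mus musculus) for inhibition (a higher number here means a weaker inhibitor, a lower number a stronger inhibitor), compound 1 reaches only a limit, > 500000 nM. Compound 2 gives 37000 nM in this assay, and compound 3 gives 3200 nM. The step of an at least 13-fold lower number from compound 1 to compound 2 (1.13 log units; beyond the scatter) is fluoro in place of amino on an aromatic carbon, and its size is known only as a bound because of the limit of > 500000 nM in this assay, at which 1 of the 3 values shown sits.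

Compound 4 carries the same kind of change, (fluoro in place of amino on an aromatic carbon), though here the carbon sits meta to a sulfanyl group rather than meta to a chloro group. The expected step of an 8.0-fold lower number from compound 3 to compound 4 (0.90 log units; beyond the scatter) rests on the measured at least 13-fold lower number from compound 1 to compound 2 (1.13 log units; beyond the scatter). Compound 4 is therefore estimated at 400 nM, between 80 nM and 2500 nM.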

Compound 4, half-maximal inhibitory concentration: 40000 nM
Compound 4: the middle estimate sits 100-fold (2.00 log units) below what was measured; measured number outside the range, above it.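

On the core of compound 3, the swap of amino for fluoro gives a 13-fold higher number from compound 3 to compound 4 (1.10 log units; beyond the scatter), so in this assay the change runs the opposite way from its direction on the core of compound 1, and the two steps truly differ: the same change on two cores in this assay, an at least 13-fold lower number (1.13 log units; beyond the scatter) from compound 1 to compound 2 and a 13-fold higher number (1.10 log units; beyond the scatter) from compound 3 to compound 4, at least 160-fold (2.22 log units) apart, beyond the scatter of two such steps

Compound 1 stands at a limit rather than a number, so the earlier step is known only as a bound: the limit of > 500000 nM in this assay, at which 1 of the 4 values shown sits.

The effect of this swap therefore does not carry over between these two cores, but the pairs do not show which difference between the cores matters.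

The compounds shown leave open how a methylamino or a methoxy group in that same place would fare on each core. Also open, as far as these compounds go, is whether a compound joining the chloro group to the chain of compound 3 would follow one step or the other.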